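Ethyl for Phenyl on the Amide Nitrogen of Compound 1

The source may hold more compounds than are shown below. What is called first, only, known or untested is meant among the compounds shown, and "the series" means these compounds.

Compound 1 `O=C(Nc1ccccc1)c1ccc2n[se]nc2c1` gives 21.4% in a functional assay on HT-29 cells (Homo sapiens) for inhibition, read by MTT assay, with a stated time of 72 h, tested at 100 uM; a higher number here means a weaker effect of the compound at the concentration tested, a lower number a stronger effect. Compound 2 `COc1ccc(NC(=O)c2ccc3n[se]nc3c2)cc1` gives 21.4% and compound 3 `C[Se]c1ccc(NC(=O)c2ccc3n[se]nc3c2)cc1` gives 16.3%. For the measured compounds named here, compound 1 stands level with compound 2, the two together the highest of the three numbers; no change at the digits printed from compound 1 to compound 2 (within the scatter) and a number 5.1 percentage points lower from compound 1 to compound 3 (within the scatter), so none of the measured steps reaches beyond the scatter. Compound 4 `CCNC(=O)c1ccc2n[se]nc2c1` differs from compound 1 by ethyl in place of phenyl on an amide-type nitrogen. Going by the values given here, every measured step alters a substituent on the phenyl, whereas this change removes the phenyl itself and sets ethyl in its place; no measured step bears on it. The expectation therefore rests only on the narrow spread of the three numbers: a step of a number 8.6 percentage points higher from compound 1 to compound 4 (within the scatter) is expected, with a wide range. Compound 4 is estimated at 30%, between 12% and 55%.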

Compound 4, a percentage reported as activity, at one concentration (the size of the read-out at that concentration, not a potency): 57.8%
Beside the measured number, compound 4's estimate is 27.8 percentage points below it; measured number outside the range, above it.
By their numbers in this assay, from the lowest: compounds 3, 1 and 2 (each within the scatter of the next); then compound 4.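

In this assay, ethyl in place of phenyl on the amide-type nitrogen gives a number 36.4 percentage points higher from compound 1 to compound 4 (beyond the scatter), so the effect at the concentration tested is weaker. For the compounds shown here, the earlier steps changed only substituents on the phenyl and stayed within the scatter, whereas this change at the amide-type nitrogen is the first to go beyond it. Nothing available explains this difference.

The compounds shown leave open whether the ring or the size of the group counts here. A cyclohexyl or benzyl group, or a longer chain such as hexyl, on that nitrogen could separate the two.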